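From 2,6-dichlorophenyl to 2,4-dichlorophenyl on a shared core

The source may hold more compounds than are shown below. What is called first, only, known or untested is meant among the compounds shown, and "the series" means these compounds.

In a functional assay (muscle tissue) with Cavia porcellus as the target (on this read-out lower numbers stand for an effect already at smaller amounts and higher numbers for an effect only at larger amounts of compound), compound 3 `COC(=O)C1=C(C)N=C(C)/C(=C(\O)OC)C1c1c(Cl)cccc1Cl` gives 1.91 nM, the lowest of the three numbers measured. Compound 1 `COC(=O)C1=C(C)N=C(C)/C(=C(\O)OC)C1c1ccccc1I` gives 46.8 nM and compound 2 `COC(=O)C1=C(C)N=C(C)/C(=C(\O)OC)C1c1ccccc1OC` gives 57.5 nM, with a 1.2-fold higher number from compound 1 to compound 2 (0.09 log units; within the scatter). Compound 4 `COC(=O)C1=C(C)N=C(C)/C(=C(\O)OC)C1c1ccc(Cl)cc1Cl` carries 2,4-dichlorophenyl in place of 2,6-dichlorophenyl on a saturated ring carbon. For the measured compounds named here, two measured steps bear on this change: a 25-fold lower number from compound 1 to compound 3 (1.39 log units; beyond the scatter) and a 30-fold lower number from compound 2 to compound 3 (1.48 log units; beyond the scatter). So far, only the 2,6-dichlorophenyl group has given a low number, but no measured compound carries 2,4-dichlorophenyl, so the expectation is uncertain. A large step of similar size is expected in this assay, namely a 21-fold higher number from compound 3 to compound 4 (1.32 log units; beyond the scatter). Compound 4 is estimated at 40 nM, with an expected range from 10 nM to 150 nM.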

Compound 4, half-maximal effective concentration: 640 nM
Compound 4: middle estimate off by 16-fold (1.20 log units), on the low side, and the stated range ends below it.
By their numbers in this assay, from the lowest: compound 3; then compounds 1 and 2 (each within the scatter of the next); then compound 4.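

In this assay, the same atoms joined differently give a 340-fold higher number from compound 3 to compound 4 (2.53 log units; beyond the scatter) and so show that the placing of the two chlorines on this phenyl group decides the outcome, not their presence alone. Set against the groups with a single substituent, 2,4-dichlorophenyl gives an 11-fold higher number from compound 2 to compound 4 (1.05 log units; beyond the scatter) and a 14-fold higher number from compound 1 to compound 4 (1.14 log units; beyond the scatter), so a second chlorine does not by itself bring a lower number. Nothing available accounts for this difference. Still open, as far as these compounds go, is how a phenyl group carrying an amine or a carboxylic acid would behave at this position.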